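A Methoxy Added Onto a Lactone-Bearing Styryl Scaffold

The source may hold more compounds than are shown below. What is called first, only, known or untested is meant among the compounds shown, and "the series" means these compounds.

Measured compounds:
compound 1, `COc1ccc(/C=C/C2CC(=O)C=CO2)cc1OC`: 146 uM
compound 2, `COc1cc(/C=C/C2CC(=O)C=CO2)cc(OC)c1OC`: 223 uM
compound 3, `COc1ccc(/C=C/C2CC=CC(=O)O2)cc1`: 17.3 uM

In a functional assay on NCI/ADR cells (Homo sapiens) for inhibition, read by sulforhodamine B assay, with a stated time of 48 h (on this read-out lower numbers stand for stronger inhibition of growth and higher numbers for weaker inhibition of growth), compound 1 gives 146 uM, and compound 2 gives 223 uM. The change from compound 1 to compound 2 is methoxy in place of hydrogen on an aromatic carbon, and the step it made is a 1.5-fold higher number from compound 1 to compound 2 (0.18 log units; within the scatter). Compound 3 has a different core, and the difference between the two cores is not broken down here. In this assay compound 3 gives 17.3 uM, the lowest of the three numbers, well apart from both compound 1 and compound 2.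

Compound 4, `COc1ccc(/C=C/C2CC=CC(=O)O2)c(OC)c1`, has not been measured. Its difference from compound 3 is methoxy in place of hydrogen on an aromatic carbon. The surroundings are not identical: in compound 2 the new methoxy sits ortho to a methoxy group and meta to a group of 9 heavy atoms, while in compound 4 it sits ortho to a group of 9 heavy atoms and meta to a methoxy group, so this is the same kind of change, not the same change. Because a 1.5-fold higher number from compound 1 to compound 2 (0.18 log units; within the scatter) lies within the scatter, the expected step from compound 3 to compound 4 in this assay is a 1.3-fold higher number from compound 3 to compound 4 (0.10 log units; within the scatter), a small one. Compound 4 is therefore estimated at 22 uM, expected to fall between 9 uM and 55 uM.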

Compound 4, concentration for growth inhibition (reported as GI): 8.8 uM
The estimate for compound 4 lay 2.5-fold (0.40 log units) above the measured number, outside the stated range (below it).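

In this assay, the same methoxy-for-hydrogen change on the second core gives a 2.0-fold lower number from compound 3 to compound 4 (0.29 log units; within the scatter), and set beside the first case the two steps do not agree: the same change on two cores in this assay, a 1.5-fold higher number (0.18 log units; within the scatter) from compound 1 to compound 2 and a 2.0-fold lower number (0.29 log units; within the scatter) from compound 3 to compound 4, 3.0-fold (0.48 log units) apart, beyond the scatter of two such steps

Each step taken alone lies within the scatter, so neither one shows on its own that the methoxy alters growth inhibition, yet the gap between them means that the step seen on one core should not simply be copied to the other in this series. This does not show that the core alone sets the outcome, since the new methoxy also sits in a different place in the two pairs, ortho to a group of 9 heavy atoms in compound 4.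

The compounds shown leave open how the change would behave in one identical place on both cores. They also leave open whether a hydroxyl group, an amine or a carboxylic acid on the aromatic ring would follow the methoxy steps.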